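This account rests on a few compounds, and the source may have more. Where it says the series, first, only, none or still open, it means among the compounds named here.

Three compounds of this series have numbers in a functional assay on HepG2 cells (Homo sapiens) for antiproliferative activity, read by MTT assay, with a stated time of 72 h; on this read-out higher numbers stand for weaker inhibition and lower numbers for stronger inhibition. Compound 1 `Cc1nn(C)c(Oc2ccc(F)cc2)c1/C=N\CCCCCCOc1cc2oc(=O)cc(C)c2cc1Cl` gives 12500 nM. Compound 2 `Cc1nn(C)c(Oc2cccc(Cl)c2)c1/C=N\CCCCCCOc1cc2oc(=O)cc(C)c2cc1Cl` gives 6220 nM. Compound 3 `Cc1ccc(Oc2c(/C=N\CCCCCCOc3cc4oc(=O)cc(C)c4cc3Cl)c(C)nn2C)cc1` gives 20700 nM, the highest of the three; the step of a 1.7-fold higher number from compound 1 to compound 3 (0.22 log units; within the scatter) is within the scatter, whereas the step of a 3.3-fold higher number from compound 2 to compound 3 (0.52 log units; beyond the scatter) is beyond it. Compound 4 `Cc1nn(C)c(Oc2ccc(OC(F)(F)F)cc2)c1/C=N\CCCCCCOc1cc2oc(=O)cc(C)c2cc1Cl` has not been measured in this assay. It differs from compound 3 by trifluoromethoxy in place of methyl on an aromatic carbon, on an aromatic carbon of a six-membered aromatic ring of carbon only. The step that bears most directly on this exchange, a 1.7-fold higher number from compound 1 to compound 3 (0.22 log units; within the scatter), swapped two small groups at the same place and stayed within the scatter; the step of a 3.3-fold higher number from compound 2 to compound 3 (0.52 log units; beyond the scatter) changed the whole phenyl pattern and was modest. Within the data shown here, compound 2, carrying a chlorine on that ring, gives 6220 nM, which is the only number beyond the scatter from compound 3. No step beyond the scatter is expected here, with a slight lean toward a lower number. Compound 4 is therefore estimated at 12000 nM, with a range from 4000 nM to 36000 nM. The expected step is a 1.7-fold lower number from compound 3 to compound 4 (0.24 log units; within the scatter).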

Compound 4, half-maximal inhibitory concentration: 8160 nM
Estimate against measurement, compound 4: 1.5-fold (0.17 log units) above; the measured number falls inside the stated range.
By their numbers in this assay, from the lowest: compounds 2, 4, 1 and 3 (each within the scatter of the next, the first and the last beyond it).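

In this assay, the change from 4-methylphenyl to 4-(trifluoromethoxy)phenyl gives a step beyond the scatter (a 2.5-fold lower number from compound 3 to compound 4 (0.40 log units; beyond the scatter)), whereas the earlier exchange of fluoro for methyl at this place stayed within it (a 1.7-fold higher number from compound 1 to compound 3 (0.22 log units; within the scatter)), so a single substituent at this place can shift the number modestly. The two other new steps (a 1.3-fold higher number from compound 2 to compound 4 (0.12 log units; within the scatter); a 1.5-fold lower number from compound 1 to compound 4 (0.19 log units; within the scatter)) stay within the scatter, so the trifluoromethoxy compound cannot be separated from the 3-chlorophenyl or the 4-fluorophenyl compound, and only the methyl compound stands apart from it. Nothing available gives a reason for these steps.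

The compounds shown leave open whether an amine or a carboxylic acid on this phenyl ring would move the number further than these modest steps. They also leave open how a shorter chain between the imine and the core would read in this series.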